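Enlarging the hydroxylated ring on the shared core

The source may report more compounds than this note shows. Statements on the series, on what has been measured and on what is new or still open speak of the compounds shown alone.

Among the measured compounds shown here, compound 1 `N#Cc1cnc(NCc2cnccc2C(F)(F)F)cc1N[C@H]1C[C@@H](O)C1` sits at the upper limit of an assay on isolated protein for inhibition of protein kinase C delta type (Homo sapiens), read by TR-FRET, with a stated time of 2 h (a lower number here means a stronger inhibitor, a higher number a weaker inhibitor), where the assay reports only that its value is > 10000 nM and no number (the limit of > 10000 nM in this assay, at which 1 of the 3 values shown sits). Compound 2 `N#Cc1cnc(NCc2ccccc2C(F)(F)F)cc1N[C@H]1CC[C@@H](O)CC1` gives 4500 nM in this assay, and compound 3 `CC(C)(C)Oc1ncncc1CNc1cc(N[C@H]2CC[C@@H](O)CC2)c(C#N)cn1` gives 200 nM. Compound 4 `CC1(C)C[C@@H](Nc2cc(NCc3cnccc3C(F)(F)F)ncc2C#N)CC[C@H]1O`, not yet measured, differs from compound 1 by 4-hydroxy-3,3-dimethylcyclohexyl in place of 3-hydroxycyclobutyl on a nitrogen on an aromatic ring. For the measured compounds named here, no step between measured compounds covers this change, so what follows is an expectation only: since compound 1 reaches only a limit, a gain is expected, of a size an at least 3.3-fold lower number from compound 1 to compound 4 (0.52 log units; beyond the scatter), beyond the usual scatter but with wide uncertainty. Compound 4 is therefore estimated at 3000 nM in this assay, with a range from 800 nM to 15000 nM.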

Compound 4, half-maximal inhibitory concentration: 2400 nM
Beside the measured number, compound 4's estimate is 1.3-fold (0.10 log units) above it; the range from low to high includes it.
By their numbers in this assay, from the lowest: compound 3; then compounds 4 and 2 (each within the scatter of the next). At a limit, above all of these: compound 1.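

Among the compounds shown here, with the rest of the shared core unchanged, this is the first comparison in which only the group on a nitrogen on an aromatic ring changes. In this assay, on these data alone, 4-hydroxy-3,3-dimethylcyclohexyl in place of 3-hydroxycyclobutyl brings an at least 4.1-fold lower number from compound 1 to compound 4 (0.61 log units; beyond the scatter), so this position responds to the change, though the full size of the step stays unknown. Compound 1 stands only at a limit of the assay: the limit of > 10000 nM in this assay, at which 1 of the 4 values shown sits.

The compounds shown leave open whether the six-membered ring or its two methyl groups carry the step. They also leave open how an amine in place of the hydroxyl on that ring would read.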